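Replacing an aryl amide with a pyridylmethyl amide

The source may report more compounds than this note shows. Statements on the series, on what has been measured and on what is new or still open speak of the compounds shown alone.

Compound 1 `O=C(Nc1ccc(Cl)cc1)c1c(O)c2cccnc2n(-c2ccccc2)c1=O`: 11.6%
Compound 2 `O=C(Nc1cccc(Cl)c1)c1c(O)c2cccnc2n(-c2ccccc2)c1=O`: 7.6%
Compound 3 `COc1ccccc1NC(=O)c1c(O)c2cccnc2n(-c2ccccc2)c1=O`: 8.1%

All three measured compounds share one core and differ only in the ring on the amide-type nitrogen. In a functional assay on the whole organism for inhibition, with Rattus norvegicus as the target, read by paw edema, at a dose of 100 mg/kg by the oral route (a higher number here means more inhibition at the dose given (going by the name of the read-out), a lower number less inhibition), compound 3 gives 8.1%, the second highest of the three numbers, but every gap is small: a number 0.5 percentage points higher from compound 2 to compound 3 (within the scatter), and a number 3.5 percentage points lower from compound 1 to compound 3 (within the scatter). Compound 4 `O=C(NCc1cccnc1)c1c(O)c2cccnc2n(-c2ccccc2)c1=O` is the next compound in this series. Its change from compound 3 is (pyridin-3-yl)methyl in place of 2-methoxyphenyl on an amide-type nitrogen. The measured steps that bear on it are all swaps of one ring on that same nitrogen: a number 4 percentage points lower from compound 1 to compound 2 (within the scatter), a number 3.5 percentage points lower from compound 1 to compound 3 (within the scatter) and a number 0.5 percentage points higher from compound 2 to compound 3 (within the scatter), none beyond the scatter. None of them, however, inserts a methylene between the nitrogen and the ring or puts a hetero atom into the ring, so the change to compound 4 goes further than anything measured. On the evidence of these flat steps, compound 4 is expected to show a number 0.9 percentage points higher from compound 3 to compound 4 (within the scatter), nothing beyond the scatter. Compound 4 is therefore estimated at 9%, within a range of 0% to 25%.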

Compound 4, a percentage reported as inhibition, in the whole organism at one dose (the size of the read-out at that dose, not a potency): 25.5%
Compound 4: middle estimate off by 16.5 percentage points, on the low side; the measured number lies above the stated range.
By their numbers in this assay, from the lowest: compounds 2, 3 and 1 (each within the scatter of the next); then compound 4.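

Swaps among the aryl rings on this amide-type nitrogen stayed within the scatter, but the (pyridin-3-yl)methyl group changes the picture: in this assay the step is a number 17.4 percentage points higher from compound 3 to compound 4 (beyond the scatter) and the other two steps are a number 17.9 percentage points higher from compound 2 to compound 4 (beyond the scatter) and a number 13.9 percentage points higher from compound 1 to compound 4 (beyond the scatter) in the same direction. This position can therefore respond to a change, and the rise lies beyond the scatter from each of the three earlier compounds, something their flat numbers alone could not reveal. No measurement shown explains the rise.

The added methylene and the ring nitrogen arrive together in compound 4, so the compounds shown leave open which of the two goes with the rise. A plain benzyl group, a pyridin-3-yl ring directly on the nitrogen, or a longer 2-(pyridin-3-yl)ethyl chain would each separate these features.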